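The compounds below may be only part of what the source reports. "The series", "measured", "known", "first", "only" and "open" are said of these compounds alone.

Values in a functional assay on HT-29 cells (Homo sapiens) for cytotoxicity, read by MTT assay, with a stated time of 72 h (on this read-out lower numbers stand for stronger inhibition and higher numbers for weaker inhibition), for the three measured members of the series:

compound 1 `CN(C)CCn1cnnc1-c1cc(Oc2ccc(NC(=O)N/N=C/c3ccc(Cl)cc3Cl)cc2F)ccn1` — 390 nM
compound 2 `CN(C)CCn1cnnc1-c1cc(Oc2ccc(NC(=O)N/N=C/c3c[nH]c4ccccc34)cc2F)ccn1` — 1300 nM
compound 3 `CN(C)CCn1cnnc1-c1cc(Oc2ccc(NC(=O)N/N=C/c3cccc(Br)c3)cc2F)ccn1` — 380 nM

Compound 3 holds the lowest of the three numbers, but its separation from compound 1 is only a 1.0-fold lower number from compound 1 to compound 3 (0.01 log units; within the scatter), so the two cannot be ordered; only compound 2 sits clearly apart, by a 3.4-fold lower number from compound 2 to compound 3 (0.53 log units; beyond the scatter).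

Compound 4 `CN(C)CCn1cnnc1-c1cc(Oc2ccc(NC(=O)N/N=C/c3cc(Br)c(O)c(Br)c3)cc2F)ccn1` is the next member. Relative to compound 3 the change is 3,5-dibromo-4-hydroxyphenyl in place of 3-bromophenyl on a carbon with a double bond to nitrogen. Going by the values given here, every measured step so far swaps the group on the carbon with a double bond to nitrogen, so all three bear on this one. Exchanging one halogenated phenyl for another gave a 1.0-fold lower number from compound 1 to compound 3 (0.01 log units; within the scatter), while putting the 1H-indol-3-yl in and taking it out gave a 3.3-fold higher number from compound 1 to compound 2 (0.52 log units; beyond the scatter) and a 3.4-fold lower number from compound 2 to compound 3 (0.53 log units; beyond the scatter). Among the compounds with values here, no measured step adds a hydroxyl or a second bromine to this ring, so the present change has no direct precedent. On that basis the expected step of a 1.2-fold higher number from compound 3 to compound 4 (0.07 log units; within the scatter) in this assay is small, with no confident direction. Compound 4 is therefore estimated at 450 nM, with a range from 150 nM to 1300 nM.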

Compound 4, half-maximal inhibitory concentration: 2670 nM
For compound 4 the middle estimate is 5.9-fold (0.77 log units) below the measured one, outside the stated range (above it).
By their numbers in this assay, from the lowest: compounds 3 and 1 (each within the scatter of the next); then compound 2; then compound 4.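

In this assay, the group on the carbon with a double bond to nitrogen can move the number further than the first three compounds showed: 3,5-dibromo-4-hydroxyphenyl in place of 3-bromophenyl gives a 7.0-fold higher number from compound 3 to compound 4 (0.85 log units; beyond the scatter), and in place of 2,4-dichlorophenyl it gives a 6.8-fold higher number from compound 1 to compound 4 (0.84 log units; beyond the scatter). The new group also goes past the 1H-indol-3-yl, which had held the highest number, with a 2.1-fold higher number from compound 2 to compound 4 (0.31 log units; beyond the scatter), leaving compound 4 as the weakest of the four on this read-out. Bromine on the phenyl ring therefore does not by itself keep a compound level with compound 1 and compound 3, which lie within the scatter of each other, as compound 4 carries bromine and still stands clearly apart from both.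

From the compounds shown here alone, whether the hydroxyl or the added bromine carries the step stays open, as the two enter together in compound 4; a ring with the hydroxyl alone, or with a methoxy or an amine in its place, would separate them. What lies behind the step also stays open, as no measurement bearing on it is at hand.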